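The source may report more compounds than this note shows. Statements on the series, on what has been measured and on what is new or still open speak of the compounds shown alone.

Measured in a functional assay on A549 cells (Homo sapiens) for antiproliferative activity, read by MTT assay, with a stated time of 72 h; on this read-out lower numbers stand for stronger inhibition and higher numbers for weaker inhibition:
- Compound 1 `O=C(N/N=C/c1ccc(F)cc1)Nc1ccc(Oc2ccnc3[nH]ccc23)c(F)c1`: 680 nM
- Compound 2 `O=C(N/N=C/c1ccc(O)c(Br)c1)Nc1ccc(Oc2ccnc3[nH]ccc23)c(F)c1`: 9250 nM
- Compound 3 `O=C(N/N=C/c1ccc(F)cc1)Nc1ccc(Oc2ccnc3[nH]ccc23)cc1`: 1430 nM

Compound 3, at 1430 nM, stands second highest of the three numbers, with compound 1 lower and compound 2 higher. Compound 4 `CN(C)CCCn1cccc1/C=N/NC(=O)Nc1ccc(Oc2ccnc3[nH]ccc23)cc1` alters compound 3 on the carbon with a double bond to nitrogen: 1-(3-(dimethylamino)propyl)-1H-pyrrol-2-yl in place of 4-fluorophenyl on a carbon with a double bond to nitrogen.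

Among the compounds with values here, one measured step touches that place: a 14-fold higher number from compound 1 to compound 2 (1.13 log units; beyond the scatter), a large change, with 3-bromo-4-hydroxyphenyl entering. The other, a 2.1-fold higher number from compound 1 to compound 3 (0.32 log units; beyond the scatter), is modest and swaps fluoro for hydrogen, which plays no part here since compound 4 keeps the hydrogen of compound 3. So this place can matter, but one step gives no firm direction for a very different group. The expected step is therefore only a 1.4-fold higher number from compound 3 to compound 4 (0.15 log units; within the scatter), with wide uncertainty. For compound 4 the estimated value is 2000 nM, with an expected range of 400 nM to 10000 nM.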

Compound 4, half-maximal inhibitory concentration: 2660 nM
Compound 4: middle estimate off by 1.3-fold (0.12 log units), on the low side; low and high end bracket the measured number.
By their numbers in this assay, from the lowest: compound 1; then compounds 3 and 4 (each within the scatter of the next); then compound 2.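

In this assay, the step to the 1-(3-(dimethylamino)propyl)-1H-pyrrol-2-yl group gives a 1.9-fold higher number from compound 3 to compound 4 (0.27 log units; within the scatter), so a five-membered ring with a chain ending in an amine can replace 4-fluorophenyl at this place without a change beyond the scatter. Replacements here therefore need not cost as much as a 14-fold higher number from compound 1 to compound 2 (1.13 log units; beyond the scatter). Nothing measured here accounts for this result.

The compounds shown leave open whether the pyrrole ring or its amine chain governs the outcome. A plain 1-methyl-1H-pyrrol-2-yl group, lacking the dimethylamino chain, would separate the two.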